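Adding a Chloro Group: What Compound 4 Might Show

The source may report more compounds than this note shows. Statements on the series, on what has been measured and on what is new or still open speak of the compounds shown alone.

Compound 1, `COC(=O)C1=C(C)N(c2ccccc2)C=C(C)C1c1ccccc1`, in a functional assay, tested at 200 ug/mL (on this read-out higher numbers stand for a weaker effect at the one concentration tested and lower numbers for a stronger effect), gives -33.1%.
Compound 2, `COC(=O)C1=C(C)N(c2cccc(Cl)c2)C=C(C)C1c1ccccc1`, in this assay gives -23%.
Compound 3, `CC1=C(C(=O)OC(C)(C)C)C(c2ccccc2)C=CN1c1ccccc1`, in this assay gives -37.1%.

Compounds 1 and 2 differ in one place: chloro in place of hydrogen on an aromatic carbon. This single change made a step of a number 10.1 percentage points higher from compound 1 to compound 2 (beyond the scatter), so the chloro-bearing compound 2 showed a weaker effect than compound 1 at the concentration tested.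

Compound 3 carries a different ester and a different arrangement of its core; the difference between the core of compound 3 and the core of compound 1 is not broken down here. Its value in this assay lies close to that of compound 1, within the usual scatter, and clearly lower than that of compound 2.

Compound 4, `CC1=C(C(=O)OC(C)(C)C)C(c2ccccc2)C=CN1c1ccc(Cl)cc1`, has not yet been measured. It differs from compound 3 in one place: chloro in place of hydrogen on an aromatic carbon. This is the same kind of change as from compound 1 to compound 2, but not the same: in compound 2 the chloro sits meta to a large group, in compound 4 it sits para to a large group.

Resting on compound 3 at -37.1% and on the single comparable step a number 10.1 percentage points higher from compound 1 to compound 2 (beyond the scatter), compound 4 is expected to move by a number 8.1 percentage points higher from compound 3 to compound 4 (within the scatter) in this assay. Going by the values given here, the estimate for compound 4 is therefore -29%, with a range from -42% to -16%, since only one earlier example supports it and the place of the chloro is not identical.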

Compound 4, a percentage reported as activity, at one concentration (the size of the read-out at that concentration, not a potency): -34.6%
Compound 4: middle estimate off by 5.6 percentage points, on the high side, and the stated range covers the measured number.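

In this assay, the phenyl to 4-chlorophenyl change on the core of compound 3 gives a number 2.5 percentage points higher from compound 3 to compound 4 (within the scatter), so this step alone cannot be told apart from no change at all. Set beside the earlier chloro step, the result gives no firm sign that the core alters the effect of adding chloro: the same change on two cores in this assay, a number 10.1 percentage points higher (beyond the scatter) from compound 1 to compound 2 and a number 2.5 percentage points higher (within the scatter) from compound 3 to compound 4, 7.6 percentage points apart, within the scatter of two such steps. Going by these compounds alone, this does not show that the change carries over with the same size, nor that its size depends on the core: there are only two pairs, the chloro does not stand in the same place in both, and the two pairs also differ in their cores, so these influences cannot be separated.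

The compounds shown leave open what other groups on this aromatic ring, such as fluoro, methoxy or an amine, would do to the read-out on either core. They also leave open how the methyl ester and the tert-butyl ester compare on one shared core, since compound 1 and compound 3 differ in more than one place.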